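Amino Substitution on the Fused Ring of Compound 1

The source may report more compounds than this note shows. Statements on the series, on what has been measured and on what is new or still open speak of the compounds shown alone.

Measured compounds:
compound 1, `O=C(NC(=S)Nc1nc2ccccc2s1)c1ccc([N+](=O)[O-])cc1`, 33800 nM
compound 2, `O=C(NC(=S)Nc1nc2cc([N+](=O)[O-])ccc2s1)c1ccccc1`, 41600 nM
compound 3, `CCCCC(=O)NC(=S)Nc1nc2cc(Br)ccc2s1`, 45700 nM

Three thiourea compounds have been tested in a functional assay on MCF7 cells (Homo sapiens) for cytotoxicity, read by MTT assay, with a stated time of 24 h; a lower number here means a stronger inhibitor, a higher number a weaker inhibitor. Compound 1 gives 33800 nM, compound 2 gives 41600 nM and compound 3 gives 45700 nM. Compound 1 has the lowest of the three numbers, but its distance to compound 2 and to compound 3 lies within the usual scatter of this kind of measurement, so none of the three can be called stronger or weaker than another.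

The next compound, compound 4 `Nc1ccc2sc(NC(=S)NC(=O)c3ccc([N+](=O)[O-])cc3)nc2c1`, differs from compound 1 in one place: amino in place of hydrogen on an aromatic carbon. Among the measured compounds shown here, no pair of measured compounds differs in exactly this way, so there is no measured step to lean on; all three measured numbers sit close together whatever their substituents. The step in this assay from compound 1 to compound 4 is therefore expected to be none beyond the scatter, in either direction, a 1.1-fold lower number from compound 1 to compound 4 (0.05 log units; within the scatter). For compound 4 the estimate is 30000 nM, within a range from 12000 nM to 75000 nM.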

Compound 4, half-maximal inhibitory concentration: 33200 nM
For compound 4 the middle estimate is 1.1-fold (0.04 log units) below the measured one; low and high end bracket the measured number.
By their numbers in this assay, from the lowest: compounds 4, 1, 2 and 3 (each within the scatter of the next).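

In this assay, among the compounds shown here, amino in place of hydrogen on an aromatic carbon of the fused system gives a 1.0-fold lower number from compound 1 to compound 4 (0.01 log units; within the scatter), the first change at a single place that can be read here. At this position, then, adding an amino group, with its one hydrogen-bond donor and one hydrogen-bond acceptor, gives a number that cannot be told apart from that of compound 1. Nothing shown here bears on why the two numbers match.

As far as these compounds go, whether a larger group at this position, such as a methoxy group, an acetamide or a longer alkyl chain, would also stay within the scatter remains open. Also open, from the compounds shown here alone, is what replacing the nitro group of compound 1 with a carboxylic acid or an amine would do to the number.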